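From compound 2 to compound 4: an acid added

The source may hold more compounds than are shown below. What is called first, only, known or untested is meant among the compounds shown, and "the series" means these compounds.

Measured so far:
compound 1 `Cc1cc(=O)oc2c(CN(C)CC(=O)O)c(O)ccc12` gives > 100000 nM
compound 2 `CCC(=O)Oc1ccc2c(C)cc(=O)oc2c1Cc1c(C)[nH]c2ccccc12` gives 31000 nM
compound 3 `CCCOc1ccc2c(C)cc(=O)oc2c1CN1CCc2ccccc2C1` gives > 100000 nM

The three compounds were tested in an ADME assay on MT4 cells (Homo sapiens) for cytotoxicity, read by MTT assay, with a stated time of 96 h; a higher number here means that more compound is tolerated, a lower number that less compound is tolerated. For compound 1 the result is a limit of the assay, not a number. For compound 3 the result is likewise a limit. Among the compounds with values here, compound 2 thus stands as the only compound with an actual number, while the other two sit at the limit of > 100000 nM in this assay, at which 2 of the 3 values shown sit.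

Compound 4 `Cc1[nH]c2ccccc2c1Cc1c(OC(=O)CCCC(=O)O)ccc2c(C)cc(=O)oc12` is not yet measured. It differs from compound 2 by a single change: carboxymethyl in place of hydrogen on a saturated chain carbon, two bonds along the chain from a carbonyl carbon. Within the data shown here, no measured pair of compounds shares this change, so its effect can only be expected, not read off. In this assay compound 1, which also carries a carboxylic acid, reaches only a limit, and compound 2 itself is tolerated less than the other two. For compound 4 the step of a 2.3-fold higher number from compound 2 to compound 4 (0.35 log units; beyond the scatter) is expected to run toward higher tolerance, though of uncertain size. Compound 4 is therefore estimated at 70000 nM, within 25000 nM to 200000 nM.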

Compound 4, half-maximal cytotoxic concentration: 29000 nM
For compound 4 the middle estimate is 2.4-fold (0.38 log units) above the measured one; low and high end bracket the measured number.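

In this assay, the change from propanoyl to (3-carboxypropyl)carbonyl gives a 1.1-fold lower number from compound 2 to compound 4 (0.03 log units; within the scatter), so the two values lie within the scatter of each other. This is the first pair shown that differs in one place, and it shows that a saturated chain carbon, two bonds along the chain from a carbonyl carbon, can carry carboxymethyl with no step beyond the scatter in how much compound the cells tolerate. Nothing measured here gives a reason for this result.

As far as these compounds go, it remains open whether an amine or a longer chain ending in a carboxylic acid at this place would also stay within the scatter of compound 2. With a single step in hand, it is also unknown whether carboxymethyl would behave the same way on a different core.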